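A few compounds are considered here, and "the series" means these few. Any claim that something is new, unique, unknown or untested is made for them only; others in the source may bear on it.

Compound 1 `COc1ccc(-c2cc(/C=C/C(=O)c3ccc(N)cc3)[nH]n2)cc1` was examined in a functional assay on PC-3 cells (Homo sapiens) for cytotoxicity, read by sulforhodamine B assay, with a stated time of 48 h, tested at 0.1 uM (a higher number here means a weaker effect of the compound at the concentration tested, a lower number a stronger effect), where compound 1 gives 93%. Going by the values given here, the only other compound measured alongside it, compound 2 `COc1cc(-c2cc(/C=C/C(=O)c3ccc(F)c(F)c3)[nH]n2)cc(OC)c1OC`, differs from compound 1 in more than one place, so no single step connects the two; in this assay compound 2 gives 93%. On the numbers shown, compound 1 therefore stands level with compound 2 at the digits reported, and its nearest neighbour is compound 2, with no change between them within the scatter of the read-out.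

The account now follows compound 1 to compound 3 `COc1ccc(-c2cc(/C=C/C(=O)c3ccc(N)cc3)[nH]n2)cc1OC`, which has not yet been measured in this assay. The change is methoxy in place of hydrogen on an aromatic carbon. Among the compounds with values here, since both compounds measured so far sit at the same high activity reading, and no step between measured compounds is available to suggest the size of any effect, the step of a number 1 percentage points lower from compound 1 to compound 3 (within the scatter) is expected to be none beyond the scatter, in either direction. Compound 3 is accordingly estimated to give 92% in this assay, within a range from 80% to 100%.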

Compound 3, a percentage reported as activity, at one concentration (the size of the read-out at that concentration, not a potency): 95%
The estimate for compound 3 lay 3 percentage points below the measured number; low and high end bracket the measured number.
By their numbers in this assay, from the lowest: compounds 1, 2 and 3 (each within the scatter of the next).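

The step gives the series its first comparison that differs in one place: in this assay, methoxy in place of hydrogen on an aromatic carbon, ortho to a methoxy group and meta to a large group, gives a number 2 percentage points higher from compound 1 to compound 3 (within the scatter). At this position on the core of compound 1, then, adding this methoxy group produces no effect that can be told apart from the scatter at the single concentration tested, and because the read-out is not a potency, the step does not show that the two compounds would match at other concentrations. Nothing available bears on why the added group leaves the reading within the scatter.

From the compounds shown here alone, it remains open whether a different group at this same position, such as a hydroxyl, a chlorine atom or an ethoxy group, would separate from compound 1 in this assay. Also open, going by these compounds, is whether replacing the amine on the other aromatic ring, for instance with an acetamide, would move the reading beyond the scatter, or whether this methoxy step would stay as small at a higher concentration.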